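Swapping the pendant aryl on the methylated core

The source may hold more compounds than are shown below. What is called first, only, known or untested is meant among the compounds shown, and "the series" means these compounds.

Of the compounds shown here, three have been measured in a functional assay on PC-3 cells (Homo sapiens) for cytotoxicity, read by MTT assay, with a stated time of 72 h; a higher number here means a weaker inhibitor, a lower number a stronger inhibitor. Compound 1 `O=C(Nc1ccc(Oc2ccnc3[nH]ccc23)c(F)c1)c1nn(-c2ccc(Br)cc2F)ccc1=O` gives 8800 nM. Compound 2 `O=C(Nc1ccc(Oc2ccnc3[nH]ccc23)c(F)c1)c1nn(-c2ccc(Cl)c(F)c2)ccc1=O` differs from it by one change, (4-chloro-3-fluorophenyl in place of 4-bromo-2-fluorophenyl on an aromatic nitrogen), and in this assay compound 2 gives 13600 nM, so that the step is a 1.5-fold higher number from compound 1 to compound 2 (0.19 log units; within the scatter). Compound 3 `Cn1ccc2c(Oc3ccc(NC(=O)c4nn(-c5ccc(Br)cc5F)ccc4=O)cc3)ccnc21` rests on a different core; how the core of compound 3 differs from the core of compound 1 is not broken down here. In this assay compound 3 gives 20500 nM; its nearest neighbour is compound 2, at a gap within the scatter, while its gap to compound 1 lies beyond the scatter.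

Compound 4 `Cn1ccc2c(Oc3ccc(NC(=O)c4nn(-c5ccc(Cl)c(F)c5)ccc4=O)cc3)ccnc21` has not yet been measured. It relates to compound 3 as compound 2 relates to compound 1: the change is 4-chloro-3-fluorophenyl in place of 4-bromo-2-fluorophenyl on an aromatic nitrogen, and the description of the place reads the same as for the earlier pair, so this is the same change carried onto the other core. Within the data shown here, the only measured instance of it, a 1.5-fold higher number from compound 1 to compound 2 (0.19 log units; within the scatter), stayed within the scatter. Among the measured compounds shown here, the account therefore expects a step of about a 1.5-fold higher number from compound 3 to compound 4 (0.17 log units; within the scatter) in this assay, resting on compound 1 and compound 2 because a 1.5-fold higher number from compound 1 to compound 2 (0.19 log units; within the scatter) is the sole precedent. Compound 4 is thus estimated at 30000 nM, with a likely range from 12000 nM to 75000 nM.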

Compound 4, half-maximal inhibitory concentration: 32700 nM
Compound 4: the middle estimate sits 1.1-fold (0.04 log units) below what was measured; low and high end bracket the measured number.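

In this assay, among these compounds, putting 4-chloro-3-fluorophenyl in place of 4-bromo-2-fluorophenyl on the aromatic nitrogen gives a 1.6-fold higher number from compound 3 to compound 4 (0.20 log units; within the scatter), and this step can be set beside the one seen earlier on the other core: the same change on two cores in this assay, a 1.5-fold higher number (0.19 log units; within the scatter) from compound 1 to compound 2 and a 1.6-fold higher number (0.20 log units; within the scatter) from compound 3 to compound 4, 1.0-fold (0.01 log units) apart, within the scatter of two such steps For these two pairs, then, the change carries from the core of compound 1 to the core of compound 3 with no difference between the steps that this assay can resolve. Among the compounds shown here, each step is itself within the scatter, so the agreement shows only that the swap leaves the number about where it was on both cores; it does not show that the change truly weakens these compounds, and two cores are too few to support a rule for the wider series.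

What the compounds shown leave open is whether the same agreement would hold for a pendant phenyl of a different kind, such as one carrying a methoxy group or an amine in place of the halogens. Also open, on these data alone, is whether a change with a step clearly beyond the scatter on one core would carry across to the other core equally well.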